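Swapping the benzimidazolone substituent on the piperidine ring

The compounds below may be only part of what the source reports. "The series", "measured", "known", "first", "only" and "open" are said of these compounds alone.

Within the data shown here, compound 2 `CCn1c(=O)n(C2CCN(CC(O)Cn3nc(-c4ccc(Cl)c(C)c4)c4c3CCN(C(C)=O)C4)CC2)c2ccccc21` gives 310 nM in an assay on isolated protein for inhibition of cathepsin S (Homo sapiens) (a higher number here means a weaker inhibitor, a lower number a stronger inhibitor), and stands lowest of the two numbers measured so far; its nearest neighbour is compound 1 `CC(=O)N1CCc2c(c(-c3ccc(Cl)c(C)c3)nn2CC(O)CN2CCC(n3c(=O)n(C)c4ccccc43)CC2)C1`, which gives 500 nM in this assay. Among the measured compounds shown here, the one measured step, a 1.6-fold lower number from compound 1 to compound 2 (0.21 log units; within the scatter), is a methyl in place of hydrogen on a saturated chain carbon bound to an aromatic nitrogen. Compound 3 `CC(=O)N1CCc2c(c(-c3ccc(Cl)c(C)c3)nn2CC(O)CN2CCC(n3c(O)nc4cc(C)ccc43)CC2)C1` differs from compound 2 by a group of 11 heavy atoms (8 carbon, 2 nitrogen, 1 oxygen; one five-membered aromatic ring with 2 hetero atoms, one six-membered aromatic ring of carbon only) in place of a group of 12 heavy atoms (9 carbon, 2 nitrogen, 1 oxygen; one five-membered aromatic ring with 2 hetero atoms, one six-membered aromatic ring of carbon only), on a saturated ring carbon. For the measured compounds named here, the only step that bears on this change is the small one from compound 1 to compound 2, and it touches just the alkyl on the aromatic nitrogen, which compound 3 no longer carries. The expected step is therefore a 1.6-fold higher number from compound 2 to compound 3 (0.21 log units; within the scatter), with no change beyond the scatter in this assay predicted. Compound 3 is estimated at 500 nM, with a range from 200 nM to 1300 nM.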

Compound 3, half-maximal inhibitory concentration: 100 nM
Compound 3: middle estimate off by 5.0-fold (0.70 log units), on the high side, outside the stated range (below it).
By their numbers in this assay, from the lowest: compound 3; then compounds 2 and 1 (each within the scatter of the next).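

Among these compounds, at this saturated ring carbon, three ring bonds from the ring nitrogen, the 2-hydroxy-5-methyl-1H-benzimidazol-1-yl group of compound 3 gives the first changes beyond the scatter in this assay: (a 3.1-fold lower number from compound 2 to compound 3 (0.49 log units; beyond the scatter)) and (a 5.0-fold lower number from compound 1 to compound 3 (0.70 log units; beyond the scatter)). Among the compounds shown here, the earlier pair, compound 1 and compound 2, differed only in the alkyl on the aromatic nitrogen and stayed within the scatter, so this is the first sign that the group on this carbon can move the number, here with a hydrogen-bond donor in the entering group and none in the group it replaces. No measurement offered here accounts for this result.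

The compounds shown do not separate the part played by the hydroxy from that of the ring methyl in the entering group. From the compounds shown here alone, how an amine or a carboxylic acid on this benzimidazole group would fare in this assay also stays open.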